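The source may report more compounds than this note shows. Statements on the series, on what has been measured and on what is new or still open speak of the compounds shown alone.

Compound 1 `O=C1Nc2c(ccc(F)c2F)C1(c1ccccc1)c1ccc(O)cc1`: 7.1 nM
Compound 2 `O=C1Nc2c(ccc(F)c2F)C1(c1ccc(O)cc1)c1cccs1`: 82 nM

Both values come from a functional assay on MCF7 cells (Homo sapiens) for cytotoxicity, read by WST assay, with a stated time of 72 h; on this read-out higher numbers stand for weaker inhibition and lower numbers for stronger inhibition. Of the two, compound 2 has the higher number, 82 nM, and is the weaker inhibitor. For the measured compounds named here, the only measured step is a 12-fold higher number from compound 1 to compound 2 (1.06 log units; beyond the scatter), seen when thiophen-2-yl replaces phenyl on a saturated ring carbon.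

Compound 3 `O=C1Nc2c(ccc(F)c2F)C1(c1ccncc1)c1ccc(O)cc1` carries pyridin-4-yl in place of thiophen-2-yl at that same carbon: pyridin-4-yl in place of thiophen-2-yl on a saturated ring carbon. The entering ring is six-membered, like the phenyl of compound 1 at 7.1 nM, so some of the lost inhibition may return. Going by the values given here, no measured compound has a nitrogen in this ring, however, so that single step is only a loose guide. A modest move toward a lower number is expected, probably not beyond the scatter, and smaller than the measured step. The expected change is a 1.6-fold lower number from compound 2 to compound 3 (0.21 log units; within the scatter). For compound 3 the estimated value is 50 nM, with an expected range from 12 nM to 250 nM.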

Compound 3, half-maximal inhibitory concentration: 37 nM
Beside the measured number, compound 3's estimate is 1.4-fold (0.13 log units) above it; the measured number falls inside the stated range.
By their numbers in this assay, from the lowest: compound 1; then compound 3; then compound 2.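

In this assay the change to pyridin-4-yl at this saturated ring carbon lowers the number against thiophen-2-yl (a 2.2-fold lower number from compound 2 to compound 3 (0.35 log units; beyond the scatter)) but raises it against phenyl (a 5.2-fold higher number from compound 1 to compound 3 (0.72 log units; beyond the scatter)). Among these three compounds, the position therefore separates all three aromatic rings: phenyl gives the lowest number, pyridin-4-yl the middle one and thiophen-2-yl the highest, so pyridin-4-yl regains only part of the gap between the other two. Nothing measured here explains this order.

The compounds shown leave open whether a ring nitrogen elsewhere, as in pyridin-3-yl, would give a different number, and whether a non-aromatic group such as cyclohexyl would keep the inhibition at this carbon. From the compounds shown here alone, the hydroxyl group is the same in all three compounds, so the effect of a methoxy group in its place also remains open.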